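The source may hold more compounds than are shown below. What is called first, only, known or untested is meant among the compounds shown, and "the series" means these compounds.

Compound 3 `Nc1ccc(/C=C2\SC(=O)N(Cc3ccc(Cl)cc3)C2=O)cc1` stands at the higher of the two numbers in a functional assay on HeLa cells (Homo sapiens) for cytotoxicity, read by cell counting, with a stated time of 4 days (on this read-out lower numbers stand for stronger inhibition and higher numbers for weaker inhibition), where compound 3 gives 77000 nM; its nearest neighbour on that read-out is compound 1 `C=C(Br)C(=O)Nc1cccc(/C=C2\SC(=O)N(Cc3ccc(Cl)cc3)C2=O)c1`, which in this assay gives 2700 nM, a gap beyond the scatter. Compound 2 `Nc1cccc(/C=C2\SC(=O)N(Cc3cccc(F)c3)C2=O)c1` in this assay reaches only the limit > 250000 nM and yields no number. Compound 4 `Nc1cccc(/C=C2\SC(=O)N(Cc3ccc(Cl)cc3)C2=O)c1` is not yet measured; it differs from compound 3 by 3-aminophenyl in place of 4-aminophenyl on a double-bonded chain carbon bound to a double-bonded ring carbon. Among the measured compounds shown here, no measured pair isolates this change. Compound 2 carries the same 3-aminophenyl group and returns only a limit. On that basis the step of a 1.7-fold higher number from compound 3 to compound 4 (0.23 log units; within the scatter) is expected to point toward weaker inhibition, of a size within or a little beyond the scatter. Compound 4 is estimated at 130000 nM, with a range from 40000 nM to 250000 nM.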

Compound 4, half-maximal inhibitory concentration: > 250000 nM
Compound 4 ended at the assay's limit (the forecaster's own chance of this, stated with the estimate: 35%); middle value at least 1.9-fold (0.28 log units) from the limit.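

In this assay, among the compounds shown here, the first pair to isolate the change, 3-aminophenyl in place of 4-aminophenyl on a double-bonded chain carbon bound to a double-bonded ring carbon, gives an at least 3.2-fold higher number from compound 3 to compound 4 (0.51 log units; beyond the scatter). With the 3-aminophenyl group in place, the change of hydrogen in place of (1-bromoethenyl)carbonyl on the nitrogen gives an at least 92-fold higher number from compound 1 to compound 4 (1.96 log units; beyond the scatter). Compound 4 returns only a limit of the assay: the limit of > 250000 nM in this assay, at which 2 of the 4 values shown sit.

As far as these compounds go, the step between compound 2 and compound 4 cannot be read, so 4-chlorophenyl against 3-fluorophenyl stays open. From the compounds shown here alone, whether an acetyl group on that nitrogen would hold the lower number of compound 1 also stays open.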